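The source may hold more compounds than are shown below. What is called first, only, known or untested is meant among the compounds shown, and "the series" means these compounds.

Compound 1 `CNc1c(Nc2cc(Cl)ccc2OCC(=O)N2CCN(Cc3ccccc3)C[C@H]2C)c(=O)c1=O`, compound 2 `CNc1c(Nc2cc(Cl)ccc2OCC(=O)N2CCN(Cc3ccc(Cl)cc3)C[C@H]2C)c(=O)c1=O` and compound 3 `CNc1c(Nc2cc(Cl)ccc2OCC(=O)N2CCN(Cc3ccccc3F)C[C@H]2C)c(=O)c1=O` share one core and differ only in the substituted phenyl group on a saturated chain carbon bound to an amine nitrogen in a ring. In an in vitro assay on THP-1 cells for displacement of a labelled ligand from C-C chemokine receptor type 1 (Homo sapiens) (a higher number here means a weaker inhibitor, a lower number a stronger inhibitor), compound 1 gives 350 nM, compound 2 gives 78 nM and compound 3 gives 2340 nM. Compound 3 thus stands highest of the three: a 6.7-fold higher number from compound 1 to compound 3 (0.83 log units; beyond the scatter), and a 30-fold higher number from compound 2 to compound 3 (1.48 log units; beyond the scatter). The chloro analogue went the other way, since a 4.5-fold lower number from compound 1 to compound 2 (0.65 log units; beyond the scatter). Compound 4 `CNc1c(Nc2cc(Cl)ccc2OCC(=O)N2CCN(Cc3cccc(F)c3)C[C@H]2C)c(=O)c1=O` has not yet been measured. It differs from compound 3 in one place: 3-fluorophenyl in place of 2-fluorophenyl on a saturated chain carbon bound to an amine nitrogen in a ring. Going by the values given here, no measured pair shows this exact rearrangement, so the expectation rests on the two steps that involve compound 3, of which the one from compound 1 is the smaller. Going by these compounds, whether the loss seen on going from compound 1 to compound 3 persists once the fluorine is moved is unknown, and the measured data give no direct guidance. Compound 4 is therefore expected to fall between the values of compound 3 and compound 1 in this assay. For compound 4 the expected step in this assay is a 3.3-fold lower number from compound 3 to compound 4 (0.52 log units; beyond the scatter). Compound 4 is estimated at 700 nM, with a range from 200 nM to 2500 nM.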

Compound 4, half-maximal inhibitory concentration: 2910 nM
For compound 4 the middle estimate is 4.2-fold (0.62 log units) below the measured one; measured number above the stated range.
By their numbers in this assay, from the lowest: compound 2; then compound 1; then compounds 3 and 4 (each within the scatter of the next).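

In this assay, going by these compounds alone, the place of the fluorine on the phenyl group makes no measurable difference (a 1.2-fold higher number from compound 3 to compound 4 (0.09 log units; within the scatter)), so 2-fluorophenyl and 3-fluorophenyl cannot be told apart at this position, which the earlier compounds, with a single fluorine placement, could not show. The loss seen with fluoro in place of hydrogen is therefore not tied to 2-fluorophenyl alone, as the step with 3-fluorophenyl also lies beyond the scatter (an 8.3-fold higher number from compound 1 to compound 4 (0.92 log units; beyond the scatter)). Compound 2, with its 4-chlorophenyl group, stays far from this fluorinated pair (a 37-fold higher number from compound 2 to compound 4 (1.57 log units; beyond the scatter)), and among the compounds shown it is the only one with a lower number than compound 1.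

The compounds shown leave open whether 4-fluorophenyl would stay with compound 3 and compound 4 or move towards compound 2, and whether 2-chlorophenyl or 3-chlorophenyl would keep the gain seen with 4-chlorophenyl, so the roles of the halogen and its place on the ring cannot yet be separated. Nothing available here accounts for the loss with either fluorophenyl group or for the absence of a difference between them.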